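Hydroxy for amino on the cyclobutenedione series

The source may hold more compounds than are shown below. What is called first, only, known or untested is meant among the compounds shown, and "the series" means these compounds.

Measured so far:
- compound 1 `COc1cc(-c2c(-c3ccc4cc[nH]c4c3)c(=O)c2=O)cc(OC)c1OC`: 3620 nM
- compound 2 `COc1cc(-c2c(-c3ccc4[nH]ccc4c3)c(=O)c2=O)cc(OC)c1OC`: 1500 nM
- compound 3 `COc1ccc(-c2c(-c3cc(OC)c(OC)c(OC)c3)c(=O)c2=O)cc1N`: 14 nM

In a functional assay on Bel-7402 cells (Homo sapiens) for inhibition, read by MTT assay, with a stated time of 72 h (on this read-out lower numbers stand for stronger inhibition and higher numbers for weaker inhibition), compound 3 gives 14 nM, the lowest of the three numbers. The step of a 260-fold lower number from compound 1 to compound 3 (2.41 log units; beyond the scatter) and the step of a 110-fold lower number from compound 2 to compound 3 (2.03 log units; beyond the scatter) are both large and beyond the scatter, while a 2.4-fold lower number from compound 1 to compound 2 (0.38 log units; beyond the scatter) is modest. Compound 3 thus stands clearly apart from the two indolyl analogues.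

Compound 4 `COc1ccc(-c2c(-c3cc(OC)c(OC)c(OC)c3)c(=O)c2=O)cc1O` is not yet measured. It differs from compound 3 by hydroxy in place of amino on an aromatic carbon; the group that leaves and the group that enters each bring one hydrogen-bond donor and one hydrogen-bond acceptor, and the place, ortho to a methoxy group and meta to a large group, is unchanged.

Among the compounds with values here, none of the measured steps bears directly on this change: all three steps exchange one whole aryl group for another, and no pair differs only in a hydroxy against an amino. The step to compound 4 in this assay is therefore expected to be small, within or close to the scatter, in either direction. For compound 4 the estimate is 20 nM, with a range from 4 nM to 100 nM, which corresponds to an expected step of a 1.4-fold higher number from compound 3 to compound 4 (0.15 log units; within the scatter).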

Compound 4, half-maximal inhibitory concentration: 309 nM
Compound 4: the middle estimate sits 15-fold (1.19 log units) below what was measured; measured number outside the range, above it.
By their numbers in this assay, from the lowest: compound 3; then compound 4; then compound 2; then compound 1.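

In this assay, hydroxy does not stand in for amino at this place, ortho to a methoxy group and meta to a large group: the exchange gives a 22-fold higher number from compound 3 to compound 4 (1.34 log units; beyond the scatter) even though the counts of hydrogen-bond donors and acceptors match on both sides, so this one atom matters in a way the earlier whole-aryl steps could not isolate. The 3-hydroxy-4-methoxyphenyl group still keeps part of the lead over the indolyl groups, with a 4.9-fold lower number from compound 2 to compound 4 (0.69 log units; beyond the scatter) and with a 12-fold lower number from compound 1 to compound 4 (1.07 log units; beyond the scatter), so the distance of compound 3 from compound 1 and compound 2 does not rest on the amino group in full. Nothing here gives a measured reason for the gap between amino and hydroxy at this place.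

As far as these compounds go, whether a methylamino group, an acetamido group or a fluorine at the same place would sit nearer to compound 3 or to compound 4 remains open. From the compounds shown here alone, this comparison also rests on a single pair, so it remains open whether the same step would appear on a different core or with a different partner aryl group.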